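A phenyl ether replaces a benzylamine on the shared core

A few compounds are considered here, and "the series" means these few. Any claim that something is new, unique, unknown or untested is made for them only; others in the source may bear on it.

Compound 1 `Nc1cc(N)c2nc(-c3ccccc3)c(Oc3ccc(Cl)c(Cl)c3)nc2c1` in a functional assay on HCT-15 cells (Homo sapiens) for inhibition, read by sulforhodamine B assay, with a stated time of 48 h (a lower number here means that less compound is tolerated, a higher number that more compound is tolerated), gives < 100000 nM, a limit of the assay.
Compound 2 `Nc1cc(N)c2nc(-c3ccccc3)c(NCc3ccc(F)cc3)nc2c1` gives < 100000 nM, also a limit.
Compound 3 `COc1ccc(CNc2nc3cc(N)cc(N)c3nc2-c2ccccc2)cc1` gives 75900 nM.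

Compound 2 therefore stands at the limit of < 100000 nM in this assay, at which 2 of the 3 values shown sit, so no number is known for it. Compound 4 `Nc1cc(N)c2nc(-c3ccccc3)c(Oc3ccc(F)cc3)nc2c1` differs from compound 2 by 4-fluorophenoxy in place of (4-fluorobenzyl)amino on an aromatic carbon. The step that the two limits leave unreadable from compound 1 to compound 2 exchanges an aryloxy for a benzylamino group, but both ends are limits and its size cannot be read; the step that the limit leaves unreadable from compound 2 to compound 3 is likewise unreadable from one side. Among the compounds with values here, no measured step thus fixes the size of the change to compound 4. Compound 1, an aryloxy analogue, also sits at the limit. Compound 4 is expected near the same weak level, 80000 nM (range 30000 nM to 200000 nM). That would be an estimated step that the limit leaves unreadable from compound 2 to compound 4.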

Compound 4, concentration lethal to 50% of the cells: < 100000 nM
Compound 4 ended at the assay's limit; the forecaster's own chance of this, stated with the estimate: 55%; the middle value lies beyond the limit too.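

Compound 4 gives < 100000 nM, a limit, so the steps to it from compound 1 and compound 2 cannot be read. The compounds shown leave open whether 4-fluorophenoxy and (4-fluorobenzyl)amino differ at all in this assay.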